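The source may hold more compounds than are shown below. What is called first, only, known or untested is meant among the compounds shown, and "the series" means these compounds.

Of the compounds shown here, three have been tested in a functional assay on the whole organism for inhibition, with Mythimna separata as the target, with a stated time of 5 days; a lower number here means that less compound is needed, a higher number that more compound is needed for the effect. Compound 1 `CC(C)(C)n1ncc(OCc2nnc(-c3cccs3)o2)c(Cl)c1=O` gives only a limit, > 299000 nM, so its number is not known. Compound 2 `CC(C)(C)n1ncc(OCc2nnc(-c3ccccc3)o2)c(Cl)c1=O` gives 12200 nM in this assay. Compound 3 `CC(C)(C)n1ncc(OCc2nnc(-c3ccc(Cl)cc3F)o2)c(Cl)c1=O` gives 10400 nM, the lowest of the two numbers shown, though the gap to compound 2 is small: a 1.2-fold lower number from compound 2 to compound 3 (0.07 log units; within the scatter). The large steps of an at least 24-fold lower number from compound 1 to compound 2 (1.38 log units; beyond the scatter) and an at least 28-fold lower number from compound 1 to compound 3 (1.45 log units; beyond the scatter) both rest on the limit of > 299000 nM in this assay, at which 1 of the 3 values shown sits, and mark the exchange of thiophen-2-yl for a benzene ring.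

Compound 4 `CC(C)(C)n1ncc(OCc2nnc(-c3cc(F)c(Cl)cc3Cl)o2)c(Cl)c1=O` keeps the benzene ring of compound 3 and changes only its substituents: 2,4-dichloro-5-fluorophenyl in place of 4-chloro-2-fluorophenyl on an aromatic carbon. Going by the values given here, the one measured step that bears on this, a 1.2-fold lower number from compound 2 to compound 3 (0.07 log units; within the scatter), shows that swapping substituents on that benzene ring left the number within the scatter. Among the compounds with values here, no step here changes a substituted benzene ring for another substituted one, so the expectation leans on that single step.

Compound 4 is therefore expected to give about 10000 nM in this assay, with a likely range from 3000 nM to 35000 nM, meaning an estimated step of a 1.0-fold lower number from compound 3 to compound 4 (0.02 log units; within the scatter), no change beyond the scatter.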

Compound 4, half-maximal effective concentration: 23100 nM
Estimate against measurement, compound 4: 2.3-fold (0.36 log units) below, within the range that was stated.
By their numbers in this assay, from the lowest: compounds 3, 2 and 4 (each within the scatter of the next, the first and the last beyond it). At a limit, above all of these: compound 1.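

Changing the substituents on the benzene ring at this position can move the number beyond the scatter, though only modestly: a 2.2-fold higher number from compound 3 to compound 4 (0.35 log units; beyond the scatter) in this assay. Against plain phenyl, the 2,4-dichloro-5-fluorophenyl group stays within the scatter, with a 1.9-fold higher number from compound 2 to compound 4 (0.28 log units; within the scatter), so nothing here shows an advantage for this group over the unsubstituted ring. The substituted benzene ring still keeps a wide lead over thiophen-2-yl, with an at least 12-fold lower number from compound 1 to compound 4 (1.11 log units; beyond the scatter), a step that rests on the limit of compound 1 and not on a known number: the limit of > 299000 nM in this assay, at which 1 of the 4 values shown sits.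

The compounds shown leave open whether a methoxy group or an amine on this benzene ring, or a pyridine ring in its place, would lower the number. They also leave open which substituent accounts for the step to compound 4, since chlorine and fluorine change together.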